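The source may report more compounds than this note shows. Statements on the series, on what has been measured and on what is new or still open speak of the compounds shown alone.

In an ADME assay for metabolic stability, read by HPLC, in simulated gastric fluid, with a stated time of 12 h, at pH 1.2 (on this read-out higher numbers stand for a longer-lived compound and lower numbers for a shorter-lived compound), compound 1 `O=C(N[C@H](CO)C(=O)O)[C@@H]1C[C@H](O)CN1` runs to the limit of the assay and is reported as > 12 h. Its mirror image, compound 2 `O=C(O)[C@H](CO)NC(=O)[C@H]1C[C@@H](O)CN1`, likewise stops at the assay limit and is reported as > 12 h. Within the data shown here, the step that the two limits leave unreadable from compound 1 to compound 2 therefore cannot be sized, because both values sit on (the limit of > 12 h in this assay, at which 2 of the 2 values shown sit); the only structural evidence on that step is the fact that compounds 1 and 2 differ only in the configuration as drawn. Compound 3 `O=C(O)[C@H](CO)NC(=O)[C@@H]1C[C@H](O)CN1` has not yet been measured in this assay. It differs from compound 2 as follows: the two compounds have the same atoms and bonds and differ only in configuration as drawn: 2 of 3 stereo elements differ; a stereocentre at a saturated ring carbon is drawn R in compound 2 and S in compound 3; a stereocentre at a saturated ring carbon is drawn R in compound 2 and S in compound 3. Among the measured compounds shown here, the single measured step, between two compounds that differ only in configuration, gave no readable change, so the step from compound 2 to compound 3 is expected to be a number no higher from compound 2 to compound 3 (the limit leaves the size open), nothing beyond the scatter. Compound 3 is accordingly estimated to give 12 h in this assay, within a range from 6 h to 30 h, and most probably reported again only as the limit.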

Compound 3, half-life in the ADME assay: > 12 h
Compound 3 gave a limit, no number; the forecaster's own chance of this, stated with the estimate: 85%; the middle value sits exactly at the limit.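

Among these compounds, no step among compound 1, compound 2 and compound 3 can be read, since all three sit at one limit: the limit of > 12 h in the ADME assay, at which 3 of the 3 values shown sit. In a physicochemical assay for metabolic stability, read by HPLC, with a stated time of 12 h, at pH 1.2 (a lower number here means that the compound disappears faster, a higher number that the compound lasts longer), compound 2 gives > 12 h, which is a limit. In the physicochemical assay compound 3 gives > 12 h, again a limit. The compounds shown leave open what the actual half-lives are and whether configuration changes them at all.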